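Swapping the aryl on the chain: trimethoxy out, hydroxy-methoxy in

A few compounds are considered here, and "the series" means these few. Any claim that something is new, unique, unknown or untested is made for them only; others in the source may bear on it.

Measured so far:
Compound 1 `COc1cc(/C=C/C(=O)c2cccc(-n3cc(-c4ccc(Cl)cc4)[nH]c3=O)c2)ccc1O` gives 2360 nM in a functional assay on NCI-H522 cells (Homo sapiens) for inhibition; on this read-out lower numbers stand for stronger inhibition of growth and higher numbers for weaker inhibition of growth.
Compound 2 `COc1cc(/C=C/C(=O)c2cccc(-n3cc(-c4ccccc4)[nH]c3=O)c2)ccc1O` gives 2360 nM in this assay.
Compound 3 `COc1ccc(-c2cn(-c3cccc(C(=O)/C=C/c4cc(OC)c(OC)c(OC)c4)c3)c(=O)[nH]2)cc1` gives 1850 nM in this assay.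

All three share one core and differ in the aryl groups at its two ends. On the numbers shown, compound 3 sits alongside compounds 1 and 2: its gaps to both lie within the usual scatter, so the three are not separated by this assay.

Compound 4 `COc1ccc(-c2cn(-c3cccc(C(=O)/C=C/c4ccc(O)c(OC)c4)c3)c(=O)[nH]2)cc1` is the unmeasured analogue of compound 3. The change is 4-hydroxy-3-methoxyphenyl in place of 3,4,5-trimethoxyphenyl on a double-bonded chain carbon bound to a double-bonded chain carbon. The group that enters is the same aryl that compounds 1 and 2 carry on their chains.

Among the measured compounds shown here, only one measured step exists, no change at the digits printed from compound 1 to compound 2 (within the scatter), and it concerns the other aryl, so it does not bear directly on this change. What does bear on it is the comparison of compound 3 with compounds 1 and 2: the trimethoxy and the hydroxy-methoxy aryl on the chain give values within the scatter of each other. The step from compound 3 to compound 4 is therefore expected to be small, a 1.2-fold higher number from compound 3 to compound 4 (0.08 log units; within the scatter), with no clear direction. Compound 4 is estimated at 2200 nM, within a range from 1100 nM to 4500 nM.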

Compound 4, concentration for 50% growth inhibition: 3480 nM
Estimate against measurement, compound 4: 1.6-fold (0.20 log units) below; the range from low to high includes it.
By their numbers in this assay, from the lowest: compounds 3, 1, 2 and 4 (each within the scatter of the next).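

In this assay, this swap can now be read directly with the rest of the molecule held constant, and the step is small (a 1.9-fold higher number from compound 3 to compound 4 (0.27 log units; within the scatter)), so 3,4,5-trimethoxyphenyl and 4-hydroxy-3-methoxyphenyl are not separated at this place on the chain. With 4-hydroxy-3-methoxyphenyl on the chain, changes at the other aryl also stay unresolved, both for methoxy in place of hydrogen (a 1.5-fold higher number from compound 2 to compound 4 (0.17 log units; within the scatter)) and for methoxy in place of chloro (a 1.5-fold higher number from compound 1 to compound 4 (0.17 log units; within the scatter)). Nothing available gives a measured reason for these values.

The compounds shown leave open whether any group at this place can move the number beyond the scatter. An amine or a carboxylic acid on this aryl would test that, as would a longer chain.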